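Removing the chloro group from the anilide of compound 3

The source may hold more compounds than are shown below. What is called first, only, known or untested is meant among the compounds shown, and "the series" means these compounds.

Compound 1, `COc1ccc(/C=C2\NC(=O)N(CC(=O)Nc3ccc(OC)cc3)C2=O)cc1`, gives in a functional assay on U-251 cells (Homo sapiens) for inhibition, read by sulforhodamine B assay, with a stated time of 48 h (a lower number here means a stronger inhibitor of growth, a higher number a weaker inhibitor of growth), only a limit, < 100000 nM.
Compound 2, `O=C(CN1C(=O)N/C(=C\c2ccc(Cl)cc2)C1=O)Nc1ccc(Cl)cc1`, gives in this assay a value of 29500 nM.
Compound 3, `COc1ccc(/C=C2/NC(=O)N(CC(=O)Nc3cc(C(F)(F)F)ccc3Cl)C2=O)cc1`, gives in this assay a value of 63100 nM.

The three measured compounds share a core and differ in the two aryl groups. Compound 3 carries the highest of the two real numbers in this assay; compound 2 sits at a lower number, and the gap between the two lies beyond the usual scatter. The value of compound 1 is a limit of the assay and not a number, as noted above (the limit of < 100000 nM in this assay, at which 1 of the 3 values shown sits).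

Compound 4, `COc1ccc(/C=C2/NC(=O)N(CC(=O)Nc3cccc(C(F)(F)F)c3)C2=O)cc1`, has not yet been measured. It differs from compound 3 in one place: hydrogen in place of chloro on an aromatic carbon. Among the measured compounds shown here, no pair of measured compounds differs in this way, so there is no measured step to draw on. Since the change removes a single heavy atom and leaves the trifluoromethyl group and the rest of the molecule untouched, the step is expected to be small, in either direction, and likely within the scatter: a 1.0-fold higher number from compound 3 to compound 4 (0.01 log units; within the scatter). Compound 4 is therefore estimated at 65000 nM in this assay, within a range from 25000 nM to 160000 nM.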

Compound 4, concentration for total growth inhibition: 69200 nM
Estimate against measurement, compound 4: 1.1-fold (0.03 log units) below, and the stated range covers the measured number.
By their numbers in this assay, from the lowest: compound 2; then compounds 3 and 4 (each within the scatter of the next).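

In this assay, among the compounds shown here, the first step that can be read at this position is a 1.1-fold higher number from compound 3 to compound 4 (0.04 log units; within the scatter), so the two values cannot be told apart when hydrogen stands in place of chloro on this aromatic carbon, ortho to a large group and para to a trifluoromethyl group. The earlier compounds shown here could not show this, since none of them formed a pair differing in one place; the new pair shows that, with the trifluoromethyl group and the methoxy-bearing aryl group kept, the chloro group makes no difference beyond the scatter to the growth-inhibition reading. No measurement shown offers a reason for this result.

This rests on a single pair, so the compounds shown leave open whether the chloro group would matter as little on another aryl background, such as the chloro-substituted one of compound 2. They also leave open what a different group at this same aromatic carbon would do, for example an amine or a carboxylic acid, and what would follow if the trifluoromethyl group gave way to hydrogen.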